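Working notes: chloro step on compound 2

The source may report more compounds than this note shows. Statements on the series, on what has been measured and on what is new or still open speak of the compounds shown alone.

- compound 1 `O=C(Nc1ccccc1Cl)c1cc(Cl)ccc1O`: 5 ug/mL
- compound 2 `COc1cccc(NC(=O)c2cc(Cl)ccc2O)c1`: 2.3 ug/mL

In a physicochemical assay for solubility (on this read-out higher numbers stand for higher solubility and lower numbers for lower solubility), compound 2 at 2.3 ug/mL holds the lower of the two numbers, and compound 1 at 5 ug/mL stands higher by a gap beyond the usual scatter. Compound 3 `COc1ccc(Cl)c(NC(=O)c2cc(Cl)ccc2O)c1` keeps the core of compound 2 with a single change: chloro in place of hydrogen on an aromatic carbon. Among the measured compounds shown here, no measured pair shows this change on its own, so any expectation in this assay rests on thin ground. Compound 1 also carries a chloro and gives 5 ug/mL, so only a small downward step is expected, possibly none beyond the scatter. The expected change is a 1.3-fold lower number from compound 2 to compound 3 (0.11 log units; within the scatter). Compound 3 is estimated at 1.8 ug/mL, with an expected range of 0.7 ug/mL to 4.5 ug/mL.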

Compound 3, solubility: < 1 ug/mL
Compound 3: no number, only a limit; the forecaster's own chance of this, stated with the estimate: 10%; at least 1.8-fold (0.25 log units) between middle value and limit.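

In this assay, compound 3 stands at a limit and not at a number: the limit of < 1 ug/mL in this assay, at which 1 of the 3 values shown sits.

Chloro in place of hydrogen, on an aromatic carbon ortho to a large group and para to a methoxy group, is now read on its own for the first time, as an at least 2.3-fold lower number from compound 2 to compound 3 (0.36 log units; beyond the scatter). Adding the methoxy group, read with the chloro already present, comes with an at least 5.0-fold lower number from compound 1 to compound 3 (0.69 log units; beyond the scatter), so both single changes that link compound 3 to the earlier compounds end beyond the scatter.

As far as these compounds go, both steps are bounds only, and their true sizes remain unknown. From the compounds shown here alone, whether an amine or a carboxylic acid in place of the methoxy group would give a number clear of the limit in this assay remains open.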